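From a carboxy limit to a methanesulfonamido estimate

The source may hold more compounds than are shown below. What is called first, only, known or untested is meant among the compounds shown, and "the series" means these compounds.

Compound 1 `N#Cc1ccccc1S(=O)(=O)Nc1cccc2c(C#N)c[nH]c12`: 2.8 ug/mL
Compound 2 `N#Cc1c[nH]c2c(NS(=O)(=O)c3ccc(C(=O)O)cc3)cccc12`: > 100 ug/mL (a limit)

In a functional assay on MC-38 cells (Mus musculus) for antiproliferative activity (on this read-out higher numbers stand for weaker inhibition and lower numbers for stronger inhibition), compound 2 gives only a limit, > 100 ug/mL, and no number. Compound 3 `CS(=O)(=O)Nc1ccc(S(=O)(=O)Nc2cccc3c(C#N)c[nH]c23)cc1` is not yet measured. It differs from compound 2 by methanesulfonamido in place of carboxy on an aromatic carbon, para to a large group (methanesulfonamido in place of carboxy on an aromatic carbon). Going by the values given here, no measured step gauges this change. Compound 1, at 2.8 ug/mL, shows that the shared core can give a measured value in this assay, so stronger inhibition is expected. The expected step is an at least 12-fold lower number from compound 2 to compound 3 (1.09 log units; beyond the scatter). For compound 3 the estimate is 8 ug/mL, with an expected range from 1 ug/mL to 60 ug/mL.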

Compound 3, half-maximal inhibitory concentration: 1.2 ug/mL
Compound 3: middle estimate off by 6.7-fold (0.82 log units), on the high side, within the range that was stated.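

In this assay, the aromatic carbon para to a large group turns out to be a place where the choice of group matters: methanesulfonamido in place of carboxy gives an at least 83-fold lower number from compound 2 to compound 3 (1.92 log units; beyond the scatter). Activity at this place therefore does not depend on carboxy, and a larger group with no ring still gives a measured value. The step is only a lower bound, set by the limit for compound 2: the limit of > 100 ug/mL in this assay, at which 1 of the 3 values shown sits.

As far as these compounds go, whether a smaller group, such as an amine or a methyl ether, would serve as well at this place stays open. So does whether an acetamido group would match methanesulfonamido.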